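A few compounds are considered here, and "the series" means these few. Any claim that something is new, unique, unknown or untested is made for them only; others in the source may bear on it.

Working notes on the series. Compound 1 `CC1=C(SCCC(=O)OC(C[Se]C2=C(C)C(=O)c3ccccc3C2=O)C(=O)NC(C)(C)C)C(=O)c2ccccc2C1=O` gives 3000 nM in a functional assay on MCF7 cells (Homo sapiens) for cytotoxicity, read by MTT assay, with a stated time of 24 h; a higher number here means a weaker inhibitor, a lower number a stronger inhibitor. Compound 3 `CC1=C([Se]CC(OC(=O)CNC(=O)OC(C)(C)C)C(=O)NCCCCCC(=O)OCc2ccccc2)C(=O)c2ccccc2C1=O` gives 4000 nM in this assay. Compound 2 `CC1=C(SCCC(=O)OC(C[Se]c2ccccc2)C(=O)NC(C)(C)C)C(=O)c2ccccc2C1=O` gives 14000 nM in this assay, the highest number of the three; compound 3 stands nearest to it and compound 1 furthest, and both gaps lie beyond the scatter. Going by the values given here, no pair of measured compounds differs in only one place, so no measured step can be drawn on. Compound 4 `CC1=C(SCCC(=O)OC(CC[Se]c2ccccc2)C(=O)NC(C)(C)C)C(=O)c2ccccc2C1=O` is not yet measured. It differs from compound 2 as follows: a group of 8 heavy atoms (7 carbon, 1 selenium; one six-membered aromatic ring of carbon only) in place of a group of 7 heavy atoms (6 carbon, 1 selenium; one six-membered aromatic ring of carbon only), on a saturated chain carbon, two bonds along the chain from a carbonyl carbon and an oxygen next to a carbonyl group. The entering group carries one carbon more than the leaving group, and the shared core and the rest of the chain are kept. A change of this kind, one extra carbon in an otherwise unchanged chain, is expected to give no step beyond the scatter in this assay, in either direction. Compound 4 is therefore expected at about 12000 nM, with a likely range from 5000 nM to 30000 nM. The step from compound 2 to compound 4 that this estimate means is a 1.2-fold lower number from compound 2 to compound 4 (0.07 log units; within the scatter), expected to stay within the scatter.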

Compound 4, half-maximal inhibitory concentration: 26000 nM
The estimate for compound 4 lay 2.2-fold (0.34 log units) below the measured number; measured number inside the range.
By their numbers in this assay, from the lowest: compounds 1 and 3 (each within the scatter of the next); then compounds 2 and 4 (each within the scatter of the next).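

In this assay this position now has its first measured step: a 1.9-fold higher number from compound 2 to compound 4 (0.27 log units; within the scatter) is what the group of 8 heavy atoms (7 carbon, 1 selenium; one six-membered aromatic ring of carbon only) gives in place of the group of 7 heavy atoms (6 carbon, 1 selenium; one six-membered aromatic ring of carbon only). On this saturated chain carbon, two bonds along the chain from a carbonyl carbon and an oxygen next to a carbonyl group, one extra carbon therefore gives no step beyond the scatter, and compound 2 and compound 4 cannot be told apart in this read-out. No measurement at hand bears on why this step has the size it has.

This single step does not show whether a longer chain at the same place would also stay within the scatter. As far as these compounds go, what an amine or a carboxylic acid on this chain would do to the read-out also remains open.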